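Swapping a Benzyl for an Ethylphenyl on the Ketone

The source may report more compounds than this note shows. Statements on the series, on what has been measured and on what is new or still open speak of the compounds shown alone.

Measured so far in a functional assay on WI-38 VA13 cells (Homo sapiens) for cytotoxicity; a lower number here means that less compound is needed, a higher number that more compound is needed for the effect:
compound 1 `Cc1c(C(=O)c2ccc(CN(C)C)cc2)oc2cc(-c3ccccc3)cc(O)c12` gives > 4 ug/mL, which is a limit of the assay.
compound 2 `Cc1c(C(=O)Cc2ccccc2)oc2cc(-c3ccccc3)cc(O)c12` gives > 4 ug/mL, again a limit of the assay.

Compound 2 therefore stands at the limit of > 4 ug/mL in this assay, at which 2 of the 2 values shown sit, and the numbers shown cannot tell compound 2 and compound 1 apart. Compound 3 `CCc1ccc(C(=O)c2oc3cc(-c4ccccc4)cc(O)c3c2C)cc1` differs from compound 2 by 4-ethylphenyl in place of benzyl on a carbonyl carbon. Among the compounds with values here, with both measured values being limits, no measured step exists to scale this change; the step expected from it, a step that the limit leaves unreadable from compound 2 to compound 3, is none beyond the scatter. Compound 3 is estimated at 5 ug/mL, within 2 ug/mL to 12 ug/mL, with a good chance that the assay again reports only a limit.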

Compound 3, half-maximal effective concentration: > 4 ug/mL
Compound 3 gave a limit, no number; the forecaster's own chance of this, stated with the estimate: 70%; the middle value does not contradict the limit.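

Within the data shown here, compound 1, compound 2 and compound 3 each give only a limit, so no step among them can be read: the limit of > 4 ug/mL in this assay, at which 3 of the 3 values shown sit. The compounds shown leave open how much of each is needed for the effect, and whether swapping the group on the carbonyl carbon changes that amount.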